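Imidazole-chalcone chromone series: branching of the ring nitrogen substituent

This account rests on a few compounds, and the source may have more. Where it says the series, first, only, none or still open, it means among the compounds named here.

Measured so far in a functional assay on DU-145 cells (Homo sapiens) for inhibition, read by WST assay, with a stated time of 3 days; a lower number here means a stronger inhibitor, a higher number a weaker inhibitor:
compound 1, `CCCCn1ccnc1/C=C/C(=O)/C=C/c1coc2ccccc2c1=O`, 4300 nM
compound 2, `CCCCCn1ccnc1/C=C/C(=O)/C=C/c1coc2ccccc2c1=O`, 2700 nM
compound 3, `CC(C)n1ccnc1/C=C/C(=O)/C=C/c1coc2ccccc2c1=O`, 3300 nM

All three share the same core and differ only in the group on the aromatic nitrogen. From compound 1 to compound 2 the change is methyl in place of hydrogen on a saturated chain carbon, four bonds along the chain from an aromatic nitrogen, and in this assay it gives a 1.6-fold lower number from compound 1 to compound 2 (0.20 log units; within the scatter). Compound 3 differs from compound 1 by isopropyl in place of butyl on an aromatic nitrogen, with a 1.3-fold lower number from compound 1 to compound 3 (0.11 log units; within the scatter). Compound 2 and compound 3 sit close together, a 1.2-fold higher number from compound 2 to compound 3 (0.09 log units; within the scatter). Nothing among the three separates from the others beyond the usual scatter.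

Compound 4, `CCC(C)n1ccnc1/C=C/C(=O)/C=C/c1coc2ccccc2c1=O`, is not yet measured in this assay. It differs from compound 3 by methyl in place of hydrogen on a saturated chain carbon, two bonds along the chain from an aromatic nitrogen, the same kind of change as that from compound 1 to compound 2, though the place is not identical: in the earlier pair the methyl enters four bonds along the chain from the aromatic nitrogen, here two bonds along the chain from it. The earlier step, a 1.6-fold lower number from compound 1 to compound 2 (0.20 log units; within the scatter), stayed within the scatter, and compound 3 itself gives 3300 nM. A step of similar size is expected, a 1.3-fold lower number from compound 3 to compound 4 (0.12 log units; within the scatter), because the earlier one gave a 1.6-fold lower number from compound 1 to compound 2 (0.20 log units; within the scatter). For compound 4 the expected value in this assay is 2500 nM, estimated to lie between 1200 nM and 5000 nM.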

Compound 4, half-maximal inhibitory concentration: 3300 nM
For compound 4 the middle estimate is 1.3-fold (0.12 log units) below the measured one; measured number inside the range.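

In this assay, methyl in place of hydrogen on a saturated chain carbon, two bonds along the chain from an aromatic nitrogen, gives no change at the digits printed from compound 3 to compound 4 (within the scatter), and set beside the earlier methyl step the two read as follows: the same change on two cores in this assay, a 1.6-fold lower number (0.20 log units; within the scatter) from compound 1 to compound 2 and no change at the digits printed (within the scatter) from compound 3 to compound 4, 1.6-fold (0.20 log units) apart, within the scatter of two such steps. The change therefore carries from one core to the other without a detectable difference, and the sec-butyl group stays within the scatter of the two straight chains as well, with a 1.2-fold higher number from compound 2 to compound 4 (0.09 log units; within the scatter) and a 1.3-fold lower number from compound 1 to compound 4 (0.11 log units; within the scatter). Within the data shown here, this does not show that the methyl has a consistent effect, since neither step is separable from the scatter and the two pairs place the methyl at different points on the chain, so the agreement is only that of two small steps and gives no direction or size that could be carried to a further core.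

All four groups on the aromatic nitrogen are saturated chains from isopropyl to pentyl, so the series shown says nothing on whether a longer chain such as octyl, or a benzyl group, would move the number beyond the scatter. Also open, from the compounds shown here alone, is whether a chain ending in an amine or a carboxylic acid would do so.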